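This account rests on a few compounds, and the source may have more. Where it says the series, first, only, none or still open, it means among the compounds named here.

For the measured compounds named here, compound 3 `COc1cccc(OC)c1OCCNCCOc1ccccc1OCc1cccc(C)c1` sits in the middle of the three compounds measured so far. In a functional assay on PC-3 cells (Homo sapiens) for cytotoxicity, read by sulforhodamine B assay (on this read-out lower numbers stand for higher toxicity in this test and higher numbers for lower toxicity in this test), compound 3 gives 87100 nM. The unsubstituted parent compound 1 `COc1cccc(OC)c1OCCNCCOc1ccccc1OCc1ccccc1` gives 193000 nM in this assay, while compound 2 `COc1cccc(OC)c1OCCNCCOc1ccccc1OCc1cccc(Cl)c1` gives 58900 nM in this assay. The two steps from the parent are modest: a 3.3-fold lower number from compound 1 to compound 2 (0.52 log units; beyond the scatter) and a 2.2-fold lower number from compound 1 to compound 3 (0.35 log units; beyond the scatter). Between the two substituted compounds the difference is small, a 1.5-fold higher number from compound 2 to compound 3 (0.17 log units; within the scatter).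

Compound 4 `COc1cccc(OC)c1OCCNCCOc1ccccc1OCc1ccccc1[N+](=O)[O-]` carries a different group on the benzyl portion: 2-nitrophenyl in place of 3-methylphenyl on a saturated chain carbon bound to an oxygen on an aromatic ring. Going by the values given here, none of the measured steps puts a nitro group on this ring, and none places a substituent at the 2-position of the phenyl, so no step bears directly on this change. What the measured steps do show is that the two substituents tried so far, chloro and methyl, each gave a modestly lower number than hydrogen, and lay close to one another. On that basis compound 4 is expected to land near compounds 2 and 3, with a step from compound 3 that is estimated at a 1.2-fold lower number from compound 3 to compound 4 (0.09 log units; within the scatter), most likely within the scatter. Compound 4 is therefore estimated at 70000 nM in this assay, with a range from 25000 nM to 200000 nM.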

Compound 4, concentration lethal to 50% of the cells: 95500 nM
For compound 4 the middle estimate is 1.4-fold (0.13 log units) below the measured one; low and high end bracket the measured number.
By their numbers in this assay, from the lowest: compounds 2, 3 and 4 (each within the scatter of the next); then compound 1.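

Read against the parent in this assay, the 2-nitrophenyl group gives a 2.0-fold lower number from compound 1 to compound 4 (0.31 log units; beyond the scatter), so a third substituent on this ring, and the first to contain nitrogen and oxygen, also separates from the unsubstituted compound, and all three substituted compounds shown now stand on the same side of compound 1. Exchanging the substituted ring itself produces no readable change, with a 1.1-fold higher number from compound 3 to compound 4 (0.04 log units; within the scatter) and a 1.6-fold higher number from compound 2 to compound 4 (0.21 log units; within the scatter), so at this place on a saturated chain carbon bound to an oxygen on an aromatic ring, swapping 3-methylphenyl or 3-chlorophenyl for 2-nitrophenyl, which brings in hydrogen-bond acceptors, does not move compound 4 away from the other two substituted compounds. Nothing available explains why these substituted compounds stay together.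

In compound 4 both the substituent and its location on the ring differ from compounds 2 and 3, so the compounds shown cannot separate the contribution of either. They also leave open whether a ring bearing an amine or a carboxylic acid would stay with these three compounds or move away from them.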